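Widening the Amine Ring at the Urea Tail

This account rests on a few compounds, and the source may have more. Where it says the series, first, only, none or still open, it means among the compounds named here.

Measured so far:
Compound 1 `COc1ncc(-c2ccc3nc(NC(=O)NCCN4CCCC4)sc3c2)cc1NS(=O)(=O)c1ccc(F)cc1`: 360 nM
Compound 2 `CNC(=O)Nc1nc2ccc(-c3cnc(OC)c(NS(=O)(=O)c4ccc(F)cc4)c3)cc2s1`: 1230 nM

In a functional assay on U-87MG ATCC cells for antiproliferative activity against U-87 MG (Homo sapiens), read by MTT assay, with a stated time of 72 h (a higher number here means a weaker inhibitor, a lower number a stronger inhibitor), compound 1 gives 360 nM, the lowest of the two numbers, while compound 2 gives 1230 nM. Among the measured compounds shown here, the only measured step, a 3.4-fold higher number from compound 1 to compound 2 (0.53 log units; beyond the scatter), shows a weaker inhibitor when hydrogen stands in place of (pyrrolidin-1-yl)methyl. Compound 3 `COc1ncc(-c2ccc3nc(NC(=O)NCCN4CCCCC4)sc3c2)cc1NS(=O)(=O)c1ccc(F)cc1` keeps a ring of this kind but alters it: piperidin-1-yl in place of pyrrolidin-1-yl on a saturated chain carbon, two bonds along the chain from an amide-type nitrogen. For the measured compounds named here, no measured step tests a change of ring size alone, so the expected change is no change at the digits printed from compound 1 to compound 3 (within the scatter), within the scatter. Compound 3 is therefore estimated at 360 nM, ranging from 150 nM to 900 nM.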

Compound 3, half-maximal inhibitory concentration: 750 nM
Beside the measured number, compound 3's estimate is 2.1-fold (0.32 log units) below it; low and high end bracket the measured number.
By their numbers in this assay, from the lowest: compound 1; then compounds 3 and 2 (each within the scatter of the next).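

Ring size itself counts at this position: a 2.1-fold higher number from compound 1 to compound 3 (0.32 log units; beyond the scatter) follows from piperidin-1-yl in place of pyrrolidin-1-yl in this assay and shows that having a ring on the chain is not the whole story. Against hydrogen, (piperidin-1-yl)methyl gives a 1.6-fold lower number from compound 2 to compound 3 (0.21 log units; within the scatter) and so does not stand clear of the scatter, unlike (pyrrolidin-1-yl)methyl. Nothing available explains why the two rings differ.

Still open, on these data alone, is how a smaller azetidine ring, an open dimethylamino group or a morpholine ring would behave here, and what a longer chain carrying the pyrrolidin-1-yl ring would do.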